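An Oxygen Enters the Five-Membered Ring on the Amine

A few compounds are considered here, and "the series" means these few. Any claim that something is new, unique, unknown or untested is made for them only; others in the source may bear on it.

Three analogues sharing one core have been measured in an assay on CHO cells for displacement of a labelled ligand from adenosine receptor A3 (Homo sapiens), read by scintillation counting, with a stated time of 3 h; on this read-out lower numbers stand for stronger inhibition and higher numbers for weaker inhibition. Compound 1 `CCn1c(-c2ccccc2)nc2c(NC3CCCCC3)ncnc21` gives 707 nM, compound 2 `CCCn1c(-c2ccccc2)nc2c(NC3CCC3)ncnc21` gives 264 nM, and compound 3 `CCCn1c(-c2ccccc2)nc2c(NC3CCCC3)ncnc21` gives 749 nM. Compound 3 thus carries the highest number of the three, though its gap to compound 1 lies within the scatter, while the step of a 2.8-fold higher number from compound 2 to compound 3 (0.45 log units; beyond the scatter) lies beyond it. Compound 4 `CCCn1c(-c2ccccc2)nc2c(NC3CCOC3)ncnc21` differs from compound 3 by one change: oxolan-3-yl in place of cyclopentyl on a nitrogen on an aromatic ring. Going by the values given here, no measured step exchanges a ring of carbon only for one with a hetero atom, so the only guide is the modest loss in a 2.8-fold higher number from compound 2 to compound 3 (0.45 log units; beyond the scatter), which concerns ring size rather than composition. For compound 4 the step of a 1.2-fold higher number from compound 3 to compound 4 (0.08 log units; within the scatter) is therefore expected to stay within the scatter. Compound 4 is estimated at 900 nM, within 350 nM to 2400 nM.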

Compound 4, inhibition constant: 2810 nM
Compound 4: middle estimate off by 3.1-fold (0.49 log units), on the low side; the whole stated range lies below it.
By their numbers in this assay, from the lowest: compound 2; then compounds 1 and 3 (each within the scatter of the next); then compound 4.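

In this assay, the make-up of the ring on the nitrogen matters, not only its size: with five heavy atoms kept in a five-membered ring, oxolan-3-yl in place of cyclopentyl gives a weaker result (a 3.8-fold higher number from compound 3 to compound 4 (0.57 log units; beyond the scatter)). Against the cyclobutyl of compound 2, the same group gives a larger loss (an 11-fold higher number from compound 2 to compound 4 (1.03 log units; beyond the scatter)). Nothing available explains either loss. Still open, as far as these compounds go, is whether a pyrrolidin-3-yl ring, with a ring nitrogen in place of the oxygen, or a cyclopentyl carrying a hydroxy group would give a similar loss.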